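Swapping dimethylamino for methyl on the shared core

This account rests on a few compounds, and the source may have more. Where it says the series, first, only, none or still open, it means among the compounds named here.

Values in a functional assay on HepG2 cells (Homo sapiens) for antiproliferative activity, read by XTT assay, with a stated time of 72 h (on this read-out higher numbers stand for weaker inhibition and lower numbers for stronger inhibition), so far:
- Compound 1 (`CNc1ncnc2c1c(-c1ccoc1)cn2[C@@H]1O[C@H](CO)[C@@H](O)[C@H]1O`) gives > 20000 nM as a limit
- Compound 2 (`CN(C)c1ncnc2c1c(-c1ccoc1)cn2[C@@H]1O[C@H](CO)[C@@H](O)[C@H]1O`) gives 12500 nM

The value of compound 1 is a limit and not a number. Compound 2 therefore holds the only number shown, at 12500 nM on this read-out. Compound 3 (`Cc1ncnc2c1c(-c1ccoc1)cn2[C@@H]1O[C@H](CO)[C@@H](O)[C@H]1O`) has not yet been measured. It carries methyl in place of dimethylamino on an aromatic carbon. Among the measured compounds shown here, the one measured step, an at least 1.6-fold lower number from compound 1 to compound 2 (0.20 log units; that floor lies within the scatter) changes only a group on that nitrogen, so it bears loosely and does not cover removal of the nitrogen. With compound 2 at 12500 nM a higher number has little room to show, so a lower number is expected in this assay with wide uncertainty. The expected change is a 4.2-fold lower number from compound 2 to compound 3 (0.62 log units; beyond the scatter) as an estimate. For compound 3 the estimated value is 3000 nM (range 300 nM to 20000 nM).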

Compound 3, half-maximal inhibitory concentration: 5320 nM
Beside the measured number, compound 3's estimate is 1.8-fold (0.25 log units) below it; the range from low to high includes it.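

In this assay, methyl in place of dimethylamino on an aromatic carbon gives a 2.3-fold lower number from compound 2 to compound 3 (0.37 log units; beyond the scatter). This is the first step shown that lies beyond the scatter with a number at both ends, and it shows that this position tolerates loss of the nitrogen without a higher number. Methyl in place of methylamino gives an at least 3.7-fold lower number from compound 1 to compound 3 (0.57 log units; beyond the scatter), but compound 1 has a limit and not a number, so that step is only a floor: the limit of > 20000 nM in this assay, at which 1 of the 3 values shown sits.

The compounds shown carry only methyl, methylamino and dimethylamino at this position, which leaves open how an unsubstituted amine, a hydroxyl or a longer chain such as ethyl would read there. On these data alone, whether the same step holds with a different group elsewhere on the shared core also remains open.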